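Urea series: removing the aminopyrimidine ether head group

The compounds below may be only part of what the source reports. "The series", "measured", "known", "first", "only" and "open" are said of these compounds alone.

Measured compounds in an assay on isolated protein for inhibition of serine/threonine-protein kinase TNNI3K (Homo sapiens); a lower number here means a stronger inhibitor, a higher number a weaker inhibitor:
- compound 1 `CNc1cc(Oc2ccc(NC(=O)Nc3cccc(C(F)(F)F)c3)cc2)ncn1`, 40 nM
- compound 2 `CN(C)c1cc(Oc2ccc(NC(=O)Nc3cccc(C(F)(F)F)c3)cc2)ncn1`, 2500 nM
- compound 3 `O=C(Nc1ccc(Oc2cc(NCCO)ncn2)cc1)Nc1cccc(C(F)(F)F)c1`, 32 nM

Compound 3 holds the lowest number of the three, though its gap to compound 1, a 1.3-fold lower number from compound 1 to compound 3 (0.10 log units; within the scatter), is within the scatter, so the two are not ordered. Compound 2 stands well apart: a 63-fold higher number from compound 1 to compound 2 (1.80 log units; beyond the scatter) and a 78-fold lower number from compound 2 to compound 3 (1.89 log units; beyond the scatter) are both large.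

Compound 4 `O=C(Nc1ccc(Oc2ccncc2)cc1)Nc1cccc(C(F)(F)F)c1` differs from compound 3 at the ether oxygen: pyridin-4-yl in place of 6-((2-hydroxyethyl)amino)pyrimidin-4-yl on an oxygen on an aromatic ring. Among the compounds with values here, no measured step covers this change; the measured steps all alter the substituent on the ring nitrogen while keeping the ring itself. They do show that this part of the molecule is sensitive: a single methyl on that nitrogen, a 63-fold higher number from compound 1 to compound 2 (1.80 log units; beyond the scatter), moved the number far beyond the scatter, and restoring a hydrogen there, a 78-fold lower number from compound 2 to compound 3 (1.89 log units; beyond the scatter), moved it back. Removing the whole (2-hydroxyethyl)amino group together with one ring nitrogen is a larger departure than either, so a weakening beyond the scatter is expected, with wide uncertainty.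

For compound 4 in this assay the estimate is 1500 nM (range 300 nM to 8000 nM), a step of a 47-fold higher number from compound 3 to compound 4 (1.67 log units; beyond the scatter) expected from compound 3.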

Compound 4, half-maximal inhibitory concentration: 50 nM
Compound 4: the middle estimate sits 30-fold (1.48 log units) above what was measured, and the stated range ends above it.
By their numbers in this assay, from the lowest: compounds 3, 1 and 4 (each within the scatter of the next); then compound 2.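

In this assay, the whole 6-((2-hydroxyethyl)amino)pyrimidin-4-yl group on the ether oxygen can be exchanged for pyridin-4-yl with no change beyond the scatter (a 1.6-fold higher number from compound 3 to compound 4 (0.19 log units; within the scatter)), and the same holds for the 6-(methylamino)pyrimidin-4-yl group of compound 1 (a 1.3-fold higher number from compound 1 to compound 4 (0.10 log units; within the scatter)), so this position does not depend on an amino substituent or on a second ring nitrogen. The same exchange starting from compound 2 gives a large step (a 50-fold lower number from compound 2 to compound 4 (1.70 log units; beyond the scatter)), which ties the high number of compound 2 to its 6-(dimethylamino)pyrimidin-4-yl group and not to the removal of a donor as such, since pyridin-4-yl has 0 hydrogen-bond donors. No supporting data are at hand to explain why these exchanges read as they do.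

Still open, on these data alone, is whether the remaining ring nitrogen matters, which a plain phenyl or a pyridin-3-yl on the ether oxygen would test. Also open, as far as these compounds go, is how pyridin-4-yl carrying its own methylamino group, or a longer chain or carboxylic acid on the amino group of compound 3, would read.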